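Working notes: chloro in place of trifluoromethyl

The source may hold more compounds than are shown below. What is called first, only, known or untested is meant among the compounds shown, and "the series" means these compounds.

Measured so far:
compound 1 `O=C(Nc1cccc(-n2cc(-c3ccncc3)c(-c3cc(O)cc(Cl)c3)n2)c1)Nc1ccc(Cl)c(Cl)c1`: 98%
compound 2 `COc1cc(Cl)cc(-c2nn(-c3cccc(NC(=O)Nc4ccc(Cl)c(C(F)(F)F)c4)c3)cc2-c2ccncc2)c1`: 112%

In a functional assay on IGROV-1 cells (Homo sapiens) for inhibition, read by sulforhodamine B assay, with a stated time of 48 h, tested at 0.01 uM (a lower number here means a stronger effect, a higher number a weaker effect of the compound at the concentration tested), compound 2 gives 112%, the higher of the two numbers, while compound 1 gives 98%, a gap beyond the usual scatter. Compound 3 `COc1cc(Cl)cc(-c2nn(-c3cccc(NC(=O)Nc4ccc(Cl)c(Cl)c4)c3)cc2-c2ccncc2)c1` is not yet measured; it differs from compound 2 by chloro in place of trifluoromethyl on an aromatic carbon. Within the data shown here, no measured pair isolates this change. With compound 2 at 112% and compound 1 at 98%, the step of a number 7 percentage points lower from compound 2 to compound 3 (within the scatter) is expected to be small, within the scatter, and if anything slightly downward. Compound 3 is estimated at 105%, with a range from 90% to 120%.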

Compound 3, a percentage reported as activity, at one concentration (the size of the read-out at that concentration, not a potency): 98%
Compound 3: the middle estimate sits 7 percentage points above what was measured; the range from low to high includes it.
By their numbers in this assay, from the lowest: compounds 1 and 3 (each within the scatter of the next); then compound 2.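

In this assay, chloro in place of trifluoromethyl on the aromatic carbon gives a number 14 percentage points lower from compound 2 to compound 3 (beyond the scatter) as a matched change, so this position does register the swap at this concentration. Methyl in place of hydrogen on the oxygen gives no change at the digits printed from compound 1 to compound 3 (within the scatter) with the 3,4-dichlorophenyl group held constant, so this oxygen change shows no effect in this pair. No evidence bears on the cause of either step. Open, going by these compounds, is how a nitrile or an amine would read in place of chloro. On these data alone, a longer chain on the oxygen is also open.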